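The source may report more compounds than this note shows. Statements on the series, on what has been measured and on what is new or still open speak of the compounds shown alone.

Among the three compounds measured so far, compound 3 `O=C(/C=C/c1ccc2c(c1)B(O)OC2)c1ccccc1F` gives the lowest number in a functional assay on MDA-MB-231 cells (Homo sapiens) for cytotoxicity, read by MTT assay, with a stated time of 48 h (a higher number here means a weaker inhibitor, a lower number a stronger inhibitor), namely 2200 nM. Compound 1 `O=C(/C=C/c1ccc2c(c1)B(O)OC2)c1ccco1` gives 7300 nM in this assay, and compound 2 `O=C(/C=C/c1ccc2c(c1)B(O)OC2)c1ccc(I)cc1` gives 14900 nM. The steps between them are all modest: a 3.3-fold lower number from compound 1 to compound 3 (0.52 log units; beyond the scatter), a 6.8-fold lower number from compound 2 to compound 3 (0.83 log units; beyond the scatter), and a 2.0-fold higher number from compound 1 to compound 2 (0.31 log units; beyond the scatter).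

Compound 4 `COCOc1ccccc1C(=O)/C=C/c1ccc2c(c1)B(O)OC2` keeps the shared core and changes only the ring on the carbonyl carbon: methoxymethoxy in place of fluoro on an aromatic carbon. Within the data shown here, none of the measured steps replaces one small group on that ring by another; each exchanges the whole ring attached to the carbonyl carbon, so they bear on this change only loosely. They show that changing this ring moves the number by modest amounts in either direction, and the widest spread seen is that from compound 2 to compound 3. A step of similar or smaller size is therefore expected for compound 4, most likely toward a somewhat higher number, as a 2.0-fold higher number from compound 3 to compound 4 (0.31 log units; beyond the scatter). Compound 4 is estimated at 4500 nM in this assay, within a range from 1500 nM to 14000 nM.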

Compound 4, half-maximal inhibitory concentration: 10200 nM
Compound 4: middle estimate off by 2.3-fold (0.36 log units), on the low side; measured number inside the range.
By their numbers in this assay, from the lowest: compound 3; then compounds 1, 4 and 2 (each within the scatter of the next, the first and the last beyond it).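

The earlier steps shown here each exchanged the whole ring on the carbonyl carbon, whereas this one keeps the ring and changes only the group on it. In this assay, methoxymethoxy in place of fluoro gives a 4.6-fold higher number from compound 3 to compound 4 (0.67 log units; beyond the scatter), so a change at this single place, on an aromatic carbon ortho to a large group, is enough to produce a modest step of the kind the whole-ring exchanges gave. Nothing available here bears on the cause of this step.

From the compounds shown here alone, it remains open whether the higher number goes with the longer chain of methoxymethoxy or with its two oxygens, and a methoxy or a hydroxyl group at the same place would help separate the two. An amine or a carboxylic acid there would show whether this position also allows a step toward a lower number than fluoro gives.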